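Notes on compound 3: 2-hydroxyethyl on an aromatic nitrogen

This account rests on a few compounds, and the source may have more. Where it says the series, first, only, none or still open, it means among the compounds named here.

Measured in a functional assay on NCI-H1993 cells (Homo sapiens) for inhibition, read by CCK-8 assay, with a stated time of 72 h; a higher number here means a weaker inhibitor, a lower number a stronger inhibitor:
compound 1 `Cc1c(C(C)n2cnc3ncc(-c4cnn(C)c4)nc32)ccc2ncccc12`: 206 nM
compound 2 `Cc1c(C(C)n2cnc3ncc(-c4cn[nH]c4)nc32)ccc2ncccc12`: 599 nM

Compound 2 has the higher of the two numbers, which makes it the weaker inhibitor of the pair. Compound 3 `Cc1c(C(C)n2cnc3ncc(-c4cnn(CCO)c4)nc32)ccc2ncccc12` is not yet measured. It differs from compound 2 by 2-hydroxyethyl in place of hydrogen on an aromatic nitrogen. Going by the values given here, only one measured step bears on this change: a 2.9-fold higher number from compound 1 to compound 2 (0.46 log units; beyond the scatter), a modest step with hydrogen in place of methyl on the same nitrogen. Among the compounds with values here, no measured compound carries the 2-hydroxyethyl group, so the expectation rests on that single step read in reverse. A lower number is expected in this assay, of similar size to that step: a 2.3-fold lower number from compound 2 to compound 3 (0.36 log units; beyond the scatter). For compound 3 the expected value is 260 nM, with an estimated range from 100 nM to 650 nM.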

Compound 3, half-maximal inhibitory concentration: 726 nM
Compound 3: middle estimate off by 2.8-fold (0.45 log units), on the low side; the whole stated range lies below it.
By their numbers in this assay, from the lowest: compound 1; then compounds 2 and 3 (each within the scatter of the next).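

In this assay, placing 2-hydroxyethyl on the aromatic nitrogen gives no separation from the 1H-pyrazol-4-yl compound (a 1.2-fold higher number from compound 2 to compound 3 (0.08 log units; within the scatter)). Substitution on this nitrogen therefore does not by itself go with the stronger inhibition seen for compound 1, and compound 3 is the case against that reading. Adding hydroxymethyl to the methyl group loses ground (a 3.5-fold higher number from compound 1 to compound 3 (0.55 log units; beyond the scatter)), which leaves compound 1 as the strongest of the three and methyl as the only group here that stands apart. Nothing available explains this result.

Open, from the compounds shown here alone, is whether ethyl on the same nitrogen would stay with compound 1 or fall with compound 3. A 2-methoxyethyl group or a terminal amine on the chain would show whether the outcome follows the chain or its end group.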